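The compounds below may be only part of what the source reports. "The series", "measured", "known", "first", "only" and "open" are said of these compounds alone.

Measured in a functional assay on CEM-DNR-bulk cells (Homo sapiens), read by MTT assay, with a stated time of 72 h; on this read-out lower numbers stand for stronger inhibition and higher numbers for weaker inhibition:
compound 1 `O=c1[nH]cnc2c1c(-c1ccoc1)cn2[C@@H]1O[C@H](CO)[C@@H](O)[C@H]1O` gives > 20000 nM, a limit of the assay.
compound 2 `CNc1ncnc2c1c(-c1ccsc1)cn2[C@@H]1O[C@H](CO)[C@@H](O)[C@H]1O` gives > 20000 nM, also a limit of the assay.
compound 3 `Nc1nc2c(c(-c3ccoc3)cn2[C@@H]2O[C@H](CO)[C@@H](O)[C@H]2O)c(=O)[nH]1` gives 15000 nM.

Compound 1 stands at the limit of > 20000 nM in this assay, at which 2 of the 3 values shown sit. Only a limit is known for it, so its place among the three cannot be fixed further than that it reads no stronger than compound 3. Among the measured compounds shown here, the single one-point step that reaches compound 1 is an at least 1.3-fold lower number from compound 1 to compound 3 (0.12 log units; that floor lies within the scatter); its floor lies within the scatter and gives no firm direction.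

Compound 4 `O=c1[nH]cnc2c1c(-c1ccccc1)cn2[C@@H]1O[C@H](CO)[C@@H](O)[C@H]1O` differs from compound 1 by phenyl in place of furan-3-yl on an aromatic carbon. For the measured compounds named here, no measured step changes the group on that carbon while the rest of the core stays fixed. Compound 2 differs from compound 1 in two places at once and itself reads only as a limit, so it cannot separate the effect of the ring change from the other change. Going by the values given here, the step to compound 4 therefore has no measured counterpart, and no movement beyond the scatter is expected in this assay.

With nothing to move it, compound 4 is expected to stay close to compound 1, an estimated a number no higher from compound 1 to compound 4 (the limit leaves the size open). Compound 4 is accordingly estimated at 20000 nM, within 8000 nM to 50000 nM, and it is expected most likely to be reported again only as a limit.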

Compound 4, half-maximal inhibitory concentration: > 20000 nM
Compound 4: only a limit was reported (the forecaster's own chance of this, stated with the estimate: 65%); the middle value sits exactly at the limit.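

In this assay compound 4 reads only as a limit, as compound 1 does, so the change from furan-3-yl to phenyl between these two compounds cannot be read: the limit of > 20000 nM in this assay, at which 3 of the 4 values shown sit.

The compounds shown leave open whether any group on that aromatic carbon shifts the read-out on the core of compound 1.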